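The compounds below may be only part of what the source reports. "The series", "measured", "known", "first", "only" and "open" are said of these compounds alone.

Measured compounds in a functional assay on HCT-116 cells (Homo sapiens) for inhibition, read by MTT assay, with a stated time of 48 h; on this read-out higher numbers stand for weaker inhibition and lower numbers for stronger inhibition:

Compound 1, `C/C=C/C(=O)N(Cc1cccc(O)c1)c1cc(OC)c(OC)c(OC)c1`, gives 6700 nM.
Compound 2, `C/C=C/C(=O)N(Cc1ccc(OC)c(Br)c1)c1cc(OC)c(OC)c(OC)c1`, gives 2800 nM.
Compound 3, `C/C=C/C(=O)N(Cc1ccc(OC)c(N)c1)c1cc(OC)c(OC)c(OC)c1`, gives 300 nM.

Compound 3 stands lowest of the three in this assay: its nearest neighbour is compound 2, a step of a 9.3-fold lower number from compound 2 to compound 3 (0.97 log units; beyond the scatter), and its furthest is compound 1, a step of a 22-fold lower number from compound 1 to compound 3 (1.35 log units; beyond the scatter), both beyond the scatter. Compound 4, `C/C=C/C(=O)N(Cc1ccc(OC)c(Cl)c1)c1cc(OC)c(OC)c(OC)c1`, has not yet been measured in this assay. It differs from compound 3 in a single place: chloro in place of amino on an aromatic carbon.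

Among the measured compounds shown here, two measured steps bear on this change. The step of a 9.3-fold lower number from compound 2 to compound 3 (0.97 log units; beyond the scatter) shows that replacing bromo by amino on that aromatic carbon lowered the number well beyond the scatter; the reverse direction, amino to a halogen, would therefore be expected to raise it. The step of a 2.4-fold lower number from compound 1 to compound 2 (0.38 log units; beyond the scatter) shows the bromo compound sitting between the hydroxy compound and the amino compound. Chloro is a halogen like bromo, so compound 4 is expected to land near compound 2 rather than near compound 3, a rise of roughly an 8.3-fold higher number from compound 3 to compound 4 (0.92 log units; beyond the scatter) in this assay. The estimate for compound 4 in this assay is 2500 nM, with a range from 1000 nM to 6500 nM.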

Compound 4, half-maximal inhibitory concentration: 1420 nM
The estimate for compound 4 lay 1.8-fold (0.25 log units) above the measured number, within the range that was stated.
By their numbers in this assay, from the lowest: compound 3; then compounds 4 and 2 (each within the scatter of the next); then compound 1.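

In this assay, amino now stands apart from two halogens at this aromatic carbon rather than from bromo alone: a 4.7-fold higher number from compound 3 to compound 4 (0.68 log units; beyond the scatter), while the two halogens are not separated, with a 2.0-fold lower number from compound 2 to compound 4 (0.29 log units; within the scatter). The 3-chloro-4-methoxyphenyl group also keeps a measurable edge over the 3-hydroxyphenyl group, with a 4.7-fold lower number from compound 1 to compound 4 (0.67 log units; beyond the scatter), but this step changes more than one substituent on the ring, so it cannot be assigned to chloro alone. No measurement on these compounds gives a reason for the separation of amino from chloro and bromo.

The compounds shown leave open whether the lower number belongs to amino specifically or extends to other groups at this position, such as methylamino, dimethylamino or acetamido, with the methoxy group ortho to them kept. A hydroxy group on this same carbon, giving a 3-hydroxy-4-methoxyphenyl group, would also help separate the contribution of the methoxy group from that of the chloro in the comparison with compound 1.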